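This account rests on a few compounds, and the source may have more. Where it says the series, first, only, none or still open, it means among the compounds named here.

Of the compounds shown here, two with a shared core have been measured in an assay on cells for displacement of a labelled ligand from adenosine receptor A1 (Homo sapiens), read by radioligand binding, with a stated time of 60 min, tested at 1 uM; a higher number here means more inhibition at the concentration tested (going by the name of the read-out), a lower number less inhibition. Compound 1 `CC1=C(C(=O)OC(C(F)(F)F)C(F)(F)F)C(c2ccsc2)NC(=O)N1` carries a thiophen-3-yl group on a saturated ring carbon, and in this assay compound 1 gives 17%. Compound 2 `CC1=C(C(=O)OC(C(F)(F)F)C(F)(F)F)C(c2cccs2)NC(=O)N1` instead carries thiophen-2-yl at that position, and in this assay compound 2 gives 9%. Among the measured compounds shown here, the single measured step, a number 8 percentage points lower from compound 1 to compound 2 (within the scatter), is within the scatter, so compound 2 stands at the lower of the two numbers without a real gap to compound 1.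

Compound 3 `CC1=C(C(=O)OC(C(F)(F)F)C(F)(F)F)C(c2ccco2)NC(=O)N1` follows by one change from compound 2: furan-2-yl in place of thiophen-2-yl on a saturated ring carbon. For the measured compounds named here, no measured step covers the exchange of a sulfur-containing for an oxygen-containing five-membered ring; the only step available is the within-scatter one from compound 1 to compound 2. Compound 3 is therefore expected to show a step of a number 1 percentage points higher from compound 2 to compound 3 (within the scatter) in this assay, none beyond the scatter. The estimate for compound 3 in this assay is 10%, with a range from -5% to 28%.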

Compound 3, a percentage reported as inhibition, at one concentration (the size of the read-out at that concentration, not a potency): 6%
Compound 3: middle estimate off by 4 percentage points, on the high side; the measured number falls inside the stated range.
By their numbers in this assay, from the lowest: compounds 3, 2 and 1 (each within the scatter of the next, the first and the last beyond it).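

In this assay furan-2-yl in place of thiophen-2-yl on the saturated ring carbon gives a number 3 percentage points lower from compound 2 to compound 3 (within the scatter) and so does not separate the two compounds, even though sulfur gives way to oxygen in the ring. Furan-2-yl in place of thiophen-3-yl gives a number 11 percentage points lower from compound 1 to compound 3 (beyond the scatter) and is the first step at this position beyond the scatter, though only a modest one. All three five-membered aromatic rings leave the inhibition small at the concentration tested, so this position has not yet given a large number with any of them.

Nothing available accounts for these numbers. As far as these compounds go, it remains open whether a phenyl ring, an amine or a carboxylic acid on this ring carbon would raise the number in this assay well beyond this narrow band.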